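Chlorothiophene for Methylthiophene on the Carbonyl Carbon

The source may hold more compounds than are shown below. What is called first, only, known or untested is meant among the compounds shown, and "the series" means these compounds.

Three compounds built on one shared core differ only in the aromatic group attached to the carbonyl carbon. Compound 1 `Cc1ccsc1C(=O)/C=C/c1ccc(N2CCCCC2)cc1` carries a 3-methylthiophen-2-yl group, and in an ADME assay on Vero cells (Chlorocebus sabaeus) for cytotoxicity, with a stated time of 5 days (on this read-out higher numbers stand for weaker inhibition and lower numbers for stronger inhibition), compound 1 gives 63900 nM. Compound 2 `Cc1csc(C(=O)/C=C/c2ccc(N3CCCCC3)cc2)c1` carries a 4-methylthiophen-2-yl group and in this assay compound 2 gives 56300 nM. Compound 3 `Cc1cc(C(=O)/C=C/c2ccc(N3CCCCC3)cc2)c(C)s1` carries a 2,5-dimethylthiophen-3-yl group and in this assay compound 3 gives 42300 nM. On the numbers shown compound 1 stands highest of the three, yet its nearest neighbour is reached by a 1.1-fold lower number from compound 1 to compound 2 (0.05 log units; within the scatter) and its furthest by a 1.5-fold lower number from compound 1 to compound 3 (0.18 log units; within the scatter), and the remaining step of a 1.3-fold lower number from compound 2 to compound 3 (0.12 log units; within the scatter) also stays within the scatter, so the three cannot be told apart.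

Compound 4 `O=C(/C=C/c1ccc(N2CCCCC2)cc1)c1ccc(Cl)s1` has not been measured in this assay. It differs from compound 1 in one place: 5-chlorothiophen-2-yl in place of 3-methylthiophen-2-yl on a carbonyl carbon. All three measured steps bear on this change. Each exchanges the ring on the carbonyl carbon while everything else is held fixed, and none moved beyond the scatter. Going by the values given here, a chlorine substituent on the thiophene has no precedent among the measured compounds, so the expectation rests on those small movements. No step beyond the scatter is therefore expected in this assay for compound 4, and the expected step is a 1.2-fold lower number from compound 1 to compound 4 (0.07 log units; within the scatter). Compound 4 is estimated at 55000 nM, with a range from 25000 nM to 120000 nM.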

Compound 4, half-maximal inhibitory concentration: 32400 nM
Compound 4: the middle estimate sits 1.7-fold (0.23 log units) above what was measured; measured number inside the range.
By their numbers in this assay, from the lowest: compounds 4, 3, 2 and 1 (each within the scatter of the next).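

Going by these compounds alone, a chlorine on the thiophene is the first halogen seen on the ring attached to the carbonyl carbon, and the result extends the flat picture at this position to a group with a different substituent atom, since in this assay the change gives a 2.0-fold lower number from compound 1 to compound 4 (0.29 log units; within the scatter) and the comparison with the other methyl-bearing ring gives a 1.7-fold lower number from compound 2 to compound 4 (0.24 log units; within the scatter) while the comparison with the dimethyl ring gives a 1.3-fold lower number from compound 3 to compound 4 (0.12 log units; within the scatter) and so leaves all four compounds indistinguishable. The entering 5-chlorothiophen-2-yl group has the same number of heavy atoms, hydrogen-bond donors and hydrogen-bond acceptors as the leaving 3-methylthiophen-2-yl group, so this position has so far been probed only with swaps that keep these counts closely matched, and none of them has produced a step beyond the scatter. Nothing is available that would explain the size of these steps, and no outside measurement bears on them.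

From the compounds shown here alone, whether a group of another kind on this ring, such as an amine or a carboxylic acid, would move the number beyond the scatter remains open. Going by these compounds, it is equally open whether a six-membered aromatic ring such as pyridine on the carbonyl carbon would stay within it.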